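The source may report more compounds than this note shows. Statements on the series, on what has been measured and on what is new or still open speak of the compounds shown alone.

Measured so far:
- compound 1, `N=C(N)NCCC[C@H](NC(=O)CN(c1nc(Cl)nc2[nH]cnc12)C1CC1)C(=O)OCc1ccccc1`: 6.12%
- compound 2, `CSCC[C@H](NC(=O)CN(c1nc(Cl)nc2[nH]cnc12)C1CC1)C(=O)OCc1ccccc1`: 17.6%

These two numbers come from a functional assay on the whole organism (Tail, strain ICR) with Mus musculus as the target, in the tail flick test, with a stated time of 150 min, at a dose of 25 umol/kg by the oral route; on this read-out higher numbers stand for a stronger effect at the one dose given and lower numbers for a weaker effect. Compound 2 gives the higher of the two; its nearest neighbour is compound 1, which is a number 11.5 percentage points higher from compound 1 to compound 2 (beyond the scatter).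

Compound 3, `NC(=O)CC[C@H](NC(=O)CN(c1nc(Cl)nc2[nH]cnc12)C1CC1)C(=O)OCc1ccccc1`, has not yet been measured. It differs from compound 2 in one place: carbamoyl in place of methylsulfanyl on a saturated chain carbon, three bonds along the chain from an amide-type nitrogen and a carbonyl carbon.

For the measured compounds named here, only one measured step exists, from compound 1 to compound 2, and it exchanged a different pair of groups at the same place, so it bears on this change only loosely. It shows that exchanging the group at this position can move the read-out by a modest amount beyond the scatter, but it does not show in which direction a carbamoyl would move it. With nothing closer to lean on, a small downward step is expected, a number 5.6 percentage points lower from compound 2 to compound 3 (within the scatter), with the whole range of the two measured compounds left open. Compound 3 is therefore estimated at 12%, between 4% and 22%.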

Compound 3, a percentage reported as activity, at one dose (the size of the read-out at that dose, not a potency): 31.1%
Estimate against measurement, compound 3: 19.1 percentage points below; the whole stated range lies below it.
By their numbers in this assay, from the lowest: compound 1; then compound 2; then compound 3.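

With carbamoyl at this position, the read-out in this assay rises, a change of a number 13.5 percentage points higher from compound 2 to compound 3 (beyond the scatter), so this place can give more than the methylsulfanyl group gave. The gain over the group of 5 heavy atoms is larger still, at a number 25 percentage points higher from compound 1 to compound 3 (beyond the scatter), which makes compound 3 the highest of the three, with both of its steps beyond the scatter. The order does not follow group size, since carbamoyl stands above both the smaller group of 2 heavy atoms and the larger group of 5, and nothing measured here explains this result.

As far as these compounds go, whether the gain belongs to the carbamoyl group itself remains open, and a carboxylic acid or a simple amine at the end of the same chain would help to test that. Whether a longer chain carrying carbamoyl would keep the gain is also unknown.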